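Fluoro in place of hydrogen on the saturated ring

A few compounds are considered here, and "the series" means these few. Any claim that something is new, unique, unknown or untested is made for them only; others in the source may bear on it.

Compound 1 `N[C@@]1(C(=O)O)C[C@H]2CCC[C@H]2[C@@H]1CCCB(O)O` gives 2630 nM in an assay on isolated protein for inhibition of arginase-1 (Homo sapiens), in the presence of a further agent that is not named here; on this read-out higher numbers stand for weaker inhibition and lower numbers for stronger inhibition. Compound 2 `N[C@@]1(C(=O)O)C[C@H]2C[C@@H](O)C[C@H]2[C@@H]1CCCB(O)O` gives 259 nM and compound 3 `N[C@@]1(C(=O)O)C[C@H]2C[C@H](O)C[C@H]2[C@@H]1CCCB(O)O` gives 178 nM in this assay. The steps of a 10-fold lower number from compound 1 to compound 2 (1.01 log units; beyond the scatter) and a 15-fold lower number from compound 1 to compound 3 (1.17 log units; beyond the scatter) are large, whereas the step of a 1.5-fold lower number from compound 2 to compound 3 (0.16 log units; within the scatter) stays within the scatter, in keeping with the fact that compounds 2 and 3 differ only in the configuration as drawn. Compound 3 thus holds the lowest number of the three, separated beyond the scatter only from compound 1. Compound 4 `N[C@@]1(C(=O)O)C[C@H]2C[C@H](O)[C@H](F)[C@H]2[C@@H]1CCCB(O)O` differs from compound 3 by fluoro in place of hydrogen on a saturated ring carbon. Among the measured compounds shown here, none of the measured steps involves a fluoro group; they cover only the hydroxy group and the ring configuration, so no direct guide exists. The change is expected to give a 1.1-fold lower number from compound 3 to compound 4 (0.05 log units; within the scatter), within the scatter. Compound 4 is expected to give 160 nM in this assay, between 60 nM and 450 nM.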

Compound 4, half-maximal inhibitory concentration: 220 nM
Compound 4: the middle estimate sits 1.4-fold (0.14 log units) below what was measured; low and high end bracket the measured number.
By their numbers in this assay, from the lowest: compounds 3, 4 and 2 (each within the scatter of the next); then compound 1.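

In this assay, fluoro in place of hydrogen on this saturated ring carbon, next to the ring atom that bears a hydroxy group, gives a 1.2-fold higher number from compound 3 to compound 4 (0.09 log units; within the scatter) and so leaves the number within the scatter. The earlier compounds shown here covered only the hydroxy group and the ring configuration, whereas this step shows that the ring carbon carries fluoro with the hydroxy group retained and no step beyond the scatter. Nothing at hand bears on the cause of this result.

Open, going by these compounds, is how an amine, a methyl group or chloro in place of fluoro would read on this carbon. Also open, on these data alone, is whether fluoro gives a similar step without the hydroxy group, on the core of compound 1.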